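This account rests on a few compounds, and the source may have more. Where it says the series, first, only, none or still open, it means among the compounds named here.

Compound 1 `Cc1ccc(N2C(=O)C/C(=C\c3cccc(C(=O)Nc4cccc(F)c4)c3)C2=O)cc1`: in an ADME assay on HCT-116 cells (Homo sapiens) for cytotoxicity, read by MTT assay, with a stated time of 72 h (on this read-out higher numbers stand for weaker inhibition and lower numbers for stronger inhibition), compound 1 gives > 100000 nM, which is a limit of the assay.
Compound 2 `CCOc1ccc(NC(=O)c2cccc(/C=C3\CC(=O)N(c4ccccc4)C3=O)c2)cc1`: in this assay compound 2 gives 84800 nM.
Compound 3 `COc1ccc(NC(=O)c2cccc(/C=C3\CC(=O)N(c4ccccc4)C3=O)c2)cc1`: in this assay compound 3 gives > 100000 nM, again a limit of the assay.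

Compound 3 therefore stands at the limit of the assay, and it is not alone there, because of the limit of > 100000 nM in this assay, at which 2 of the 3 values shown sit. The next compound, compound 4 `COc1ccc(NC(=O)c2cccc(/C=C3\CC(=O)N(c4ccc(C)cc4)C3=O)c2)cc1`, differs from compound 3 in one place: methyl in place of hydrogen on an aromatic carbon. Among the compounds with values here, the single measured step, an at least 1.1-fold higher number from compound 2 to compound 3 (0.07 log units; that floor lies within the scatter), concerns the saturated chain on the oxygen rather than the aromatic ring, and it stays within the scatter, so it gives no direct guidance on the change from hydrogen to methyl. Compound 1 does carry the 4-methylphenyl group and sits at the limit, whereas compound 2 with the plain phenyl group returns a number, but compound 1 and compound 2 differ in more than one place, so their values show only that both are weak. With compound 3 already at the limit, the change from compound 3 to compound 4 is expected to bring no step beyond the scatter, a step that the limit leaves unreadable from compound 3 to compound 4. Compound 4 is accordingly estimated at 150000 nM, in the range 60000 nM to 400000 nM, most likely reported as a limit again.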

Compound 4, half-maximal inhibitory concentration: > 100000 nM
Compound 4 gave a limit, no number; the forecaster's own chance of this, stated with the estimate: 80%; the middle value does not contradict the limit.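

No step can be read from compound 3 to compound 4 or from compound 1 to compound 4, because all three compounds stand at a limit in this assay, not at a number: the limit of > 100000 nM in this assay, at which 3 of the 4 values shown sit.

The compounds shown leave open how far phenyl to 4-methylphenyl moves the read-out, with compound 2 giving 84800 nM as the only number.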